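This account rests on a few compounds, and the source may have more. Where it says the series, first, only, none or still open, it means among the compounds named here.

Measured so far in a functional assay on SK-OV-3 cells (Homo sapiens) for inhibition, read by CCK-8 assay, with a stated time of 70 h; on this read-out lower numbers stand for stronger inhibition and higher numbers for weaker inhibition:
- compound 1 `Clc1ccc(COc2ccc(OCCOCCNC3CCCCC3)cc2)cc1`: 2650 nM
- compound 2 `Nc1ccc(COc2ccc(OCCOCCNC3CCCC3)cc2)cc1`: 31700 nM

Compound 2 has the higher of the two numbers, so it stands at the weak end of this small set. Compound 1 lies lower, by a gap beyond the scatter. The two differ in more than one place, so that gap cannot be assigned to any single group.

Compound 3 `O=Cc1ccc(COc2ccc(OCCOCCNC3CCCC3)cc2)cc1` departs from compound 2 in one place only: formyl in place of amino on an aromatic carbon, para to a large group (formyl in place of amino on an aromatic carbon). Going by the values given here, no measured pair isolates this change, so the evidence is thin. A move towards a lower number in this assay is expected, of moderate size and perhaps only just beyond the scatter. The basis is that compound 2 at 31700 nM sits at the top of the range, while compound 1 at 2650 nM shows that a compound without the amino group can read much lower. The expected size of the move is a 3.2-fold lower number from compound 2 to compound 3 (0.50 log units; beyond the scatter). For compound 3 the estimated value is 10000 nM, with an expected range of 3000 nM to 32000 nM.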

Compound 3, half-maximal inhibitory concentration: 45000 nM
Compound 3: the middle estimate sits 4.5-fold (0.65 log units) below what was measured, outside the stated range (above it).
By their numbers in this assay, from the lowest: compound 1; then compounds 2 and 3 (each within the scatter of the next).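

In this assay, formyl in place of amino on an aromatic carbon, para to a large group, gives a 1.4-fold higher number from compound 2 to compound 3 (0.15 log units; within the scatter) and so leaves the two compounds indistinguishable on this read-out. Going by these compounds alone, this is the first pair that differs in one place only, and it shows that 4-aminophenyl and 4-formylphenyl read alike here, even though the change removes the hydrogen-bond donor of the amino group and adds a double bond outside the aromatic ring. Nothing at hand explains this outcome.

Still open, going by these compounds, is whether a carboxylic acid or a nitrile on this same aromatic carbon, with the rest of compound 3 unchanged, would read any differently from amino and formyl. Also open is how the value of compound 1, 2650 nM in this assay, divides between its chloro group and its cyclohexyl group on the amine, since these two features are not separated by any single-place pair among the compounds shown.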